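Amide-nitrogen substituent swap in the cinnamyl-piperidine series

This account rests on a few compounds, and the source may have more. Where it says the series, first, only, none or still open, it means among the compounds named here.

The series shares the core of compound 1 `CCc1ccc(NC(=O)C2CCN(C/C=C/c3ccccc3)CC2)cc1` and varies the group on the amide-type nitrogen. In a functional assay on MCF7 cells (Homo sapiens) for inhibition, read by MTT assay, with a stated time of 72 h (a higher number here means a weaker inhibitor, a lower number a stronger inhibitor), compound 1 gives 20000 nM, the highest of the three numbers. Compound 2 `CCCc1ccc(NC(=O)C2CCN(C/C=C/c3ccccc3)CC2)cc1` gives 9030 nM and compound 3 `O=C(Nc1cccc(Br)c1)C1CCN(C/C=C/c2ccccc2)CC1` gives 11500 nM in this assay. The measured steps are small: a 2.2-fold lower number from compound 1 to compound 2 (0.35 log units; beyond the scatter) is the only one beyond the scatter, while a 1.7-fold lower number from compound 1 to compound 3 (0.24 log units; within the scatter) and a 1.3-fold higher number from compound 2 to compound 3 (0.11 log units; within the scatter) both lie within it.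

Compound 4 `O=C(Nc1nccs1)C1CCN(C/C=C/c2ccccc2)CC1` has not yet been measured. It differs from compound 1 in this way: 1,3-thiazol-2-yl in place of 4-ethylphenyl on an amide-type nitrogen. Among the measured compounds shown here, the steps that bear on it are the two aryl exchanges on the amide-type nitrogen, which stayed within the scatter; no measured step replaces a carbon-only ring with a ring bearing hetero atoms, so that part of the change has no precedent here. The expectation is therefore a step of about no change at the digits printed from compound 1 to compound 4 (within the scatter), with compound 4 estimated at 20000 nM in this assay, within a range from 7000 nM to 60000 nM.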

Compound 4, half-maximal inhibitory concentration: 28600 nM
For compound 4 the middle estimate is 1.4-fold (0.16 log units) below the measured one, and the stated range covers the measured number.
By their numbers in this assay, from the lowest: compounds 2, 3, 1 and 4 (each within the scatter of the next, the first and the last beyond it).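

In this assay, among the compounds shown here, the 1,3-thiazol-2-yl group is the first ring with hetero atoms on the amide-type nitrogen, and exchanging 4-ethylphenyl for it stays within the scatter (a 1.4-fold higher number from compound 1 to compound 4 (0.16 log units; within the scatter)). The same ring does separate from the other two aryl groups, beyond the scatter but modestly, against 3-bromophenyl (a 2.5-fold higher number from compound 3 to compound 4 (0.40 log units; beyond the scatter)) and against 4-propylphenyl (a 3.2-fold higher number from compound 2 to compound 4 (0.50 log units; beyond the scatter)), so this position shows a measurable spread that the earlier aryl exchanges alone did not show. No measured evidence here accounts for these steps.

Still open, as far as these compounds go, is whether an unsubstituted phenyl or a pyridin-2-yl ring on the amide-type nitrogen would sit with compound 4 or with compound 2. Also open, from the compounds shown here alone, is how an amine or a carboxylic acid on the aryl ring would read.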